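Urea to benzamide on a shared pyrazole scaffold

This account rests on a few compounds, and the source may have more. Where it says the series, first, only, none or still open, it means among the compounds named here.

Of the compounds shown here, three with a shared core have been measured in a functional assay on Hs-578T cells (Homo sapiens) for inhibition, read by sulforhodamine B assay, with a stated time of 48 h; a lower number here means a stronger inhibitor of growth, a higher number a weaker inhibitor of growth. Compound 1 `COc1cc(-c2nn(-c3cccc(NC(=O)Nc4ccc(Cl)c(Cl)c4)c3)cc2-c2ccncc2)ccc1Cl` gives 1430 nM. Compound 2 `O=C(Nc1cccc(-n2cc(-c3ccncc3)c(-c3ccc(Cl)c(O)c3)n2)c1)Nc1ccc(Cl)c(Cl)c1` gives 785 nM, and compound 3 `O=C(Nc1cccc(-n2cc(-c3ccncc3)c(-c3ccc(Cl)c(O)c3)n2)c1)Nc1cc(C(F)(F)F)cc(C(F)(F)F)c1` gives 1140 nM. Compound 1 has the highest of the three numbers, but its distance to each of the other two lies within the scatter, so no order among them can be read from these data. Within the data shown here, the one step between measured compounds that differ in a single place, a 1.8-fold lower number from compound 1 to compound 2 (0.26 log units; within the scatter), concerns a hydrogen in place of methyl on an oxygen on an aromatic ring, and it too stays within the scatter.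

Compound 4 `COc1cc(-c2nn(-c3cccc(NC(=O)c4ccccc4)c3)cc2-c2ccncc2)ccc1Cl` differs from compound 1 by phenyl in place of (3,4-dichlorophenyl)amino on a carbonyl carbon. Among the measured compounds shown here, none of the measured steps touches this part of the molecule, so there is no direct precedent among the three compounds for what the change will do. With nothing to anchor the step, the expectation is weakly held: a somewhat higher number in this assay, with wide uncertainty. Compound 4 is estimated at 4000 nM, within a range from 1000 nM to 16000 nM, which corresponds to an expected step of a 2.8-fold higher number from compound 1 to compound 4 (0.45 log units; beyond the scatter).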

Compound 4, concentration for 50% growth inhibition: 1110 nM
Beside the measured number, compound 4's estimate is 3.6-fold (0.56 log units) above it, and the stated range covers the measured number.
By their numbers in this assay, from the lowest: compounds 2, 4, 3 and 1 (each within the scatter of the next).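

In this assay, phenyl in place of (3,4-dichlorophenyl)amino on the carbonyl carbon gives a 1.3-fold lower number from compound 1 to compound 4 (0.11 log units; within the scatter), the first step shown at this end of the molecule. The change turns the urea of compound 1 into the benzamide of compound 4, removing the nitrogen with its hydrogen and the chlorine atoms in a single step, yet the difference cannot be told from ordinary repeat variation, so this assay gives no sign that the (3,4-dichlorophenyl)amino group is needed to keep growth inhibition at this level. No measurement shown here accounts for this result.

Since the nitrogen and the chlorine atoms leave together, the compounds shown cannot separate their contributions, and a benzamide carrying chlorine atoms on its phenyl ring would be needed to begin doing so. Also open, from the compounds shown here alone, is how far this position stays this forgiving when the phenyl gives way to a quite different group on the carbonyl carbon, such as a small methyl, a cyclohexyl ring or a morpholine ring.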